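Same Side-Group Swap Tested on Two Related Cores

A few compounds are considered here, and "the series" means these few. Any claim that something is new, unique, unknown or untested is made for them only; others in the source may bear on it.

Three compounds have been measured in a functional assay on MGC-803 cells (Homo sapiens) for antiproliferative activity, read by MTT assay; a higher number here means a weaker inhibitor, a lower number a stronger inhibitor:

compound 1, `Cc1ccc(NC(=O)Nc2cccc(CNc3ncnc4ccccc34)c2)cc1`, gives 31200 nM
compound 2, `COc1ccccc1NC(=O)Nc1cccc(CNc2ncnc3ccccc23)c1`, gives 39300 nM
compound 3, `COc1cc2ncnc(NCc3cccc(NC(=O)Nc4ccc(C)cc4)c3)c2cc1OC`, gives 34200 nM

Compound 1 and compound 2 share one core and differ in a single place: 2-methoxyphenyl in place of 4-methylphenyl on an amide-type nitrogen. That change produced a 1.3-fold higher number from compound 1 to compound 2 (0.10 log units; within the scatter). Compound 3 is built on a second core; the difference between the two cores is not broken down here. Compound 4, `COc1ccccc1NC(=O)Nc1cccc(CNc2ncnc3cc(OC)c(OC)cc23)c1`, has not yet been measured in this assay. It differs from compound 3 by 2-methoxyphenyl in place of 4-methylphenyl on an amide-type nitrogen, the same change at the same place as between compound 1 and compound 2. Resting on a 1.3-fold higher number from compound 1 to compound 2 (0.10 log units; within the scatter), the step from compound 3 to compound 4 is expected to be a 1.3-fold higher number from compound 3 to compound 4 (0.10 log units; within the scatter). Compound 4 is therefore estimated at 43000 nM, with a likely range from 20000 nM to 90000 nM.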

Compound 4, half-maximal inhibitory concentration: 7710 nM
Compound 4: the middle estimate sits 5.6-fold (0.75 log units) above what was measured; measured number outside the range, below it.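

The swap of 4-methylphenyl for 2-methoxyphenyl on the amide-type nitrogen, measured in this assay, gave a 4.4-fold lower number from compound 3 to compound 4 (0.65 log units; beyond the scatter) on the second core. Set beside the earlier step, the same change did not carry over from one core to the other: the same change on two cores in this assay, a 1.3-fold higher number (0.10 log units; within the scatter) from compound 1 to compound 2 and a 4.4-fold lower number (0.65 log units; beyond the scatter) from compound 3 to compound 4, 5.6-fold (0.75 log units) apart, beyond the scatter of two such steps. So, across these four compounds, the size of the step cannot be assumed to transfer between the two cores, but the data do not show which feature of the cores is responsible or how the change would behave on a third core.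

Still open, going by these compounds, is whether the lower number on the second core is specific to 2-methoxyphenyl. A plain phenyl or a chlorophenyl group in the same place could answer that.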